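The source may report more compounds than this note shows. Statements on the series, on what has been measured and on what is new or still open speak of the compounds shown alone.

Measured compounds in the series:

- compound 1, `CCc1ccc(-c2ccc(NC3=CC(=O)c4ncncc4C3=O)cc2)cc1`: 1200 nM
- compound 2, `O=C1C=CC(=O)c2ncncc21`: 18000 nM
- compound 3, `CC(=O)c1cccc(NC2=CC(=O)c3ncncc3C2=O)c1`: 900 nM

In a functional assay on PANC-1 cells (Homo sapiens) for cytotoxicity, read by MTT assay, with a stated time of 72 h (on this read-out higher numbers stand for weaker inhibition and lower numbers for stronger inhibition), compound 1 gives 1200 nM, the second highest of the three numbers. Compound 3 sits closest, with 900 nM; the gap between compound 1 and compound 3 is within the scatter, so the two are not distinguished here. Compound 2, the bare core, gives 18000 nM, a gap from compound 1 that is beyond the scatter; both compound 1 and compound 3 carry an anilino substituent on that core, and both stand well apart from compound 2.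

Compound 4, `O=C1C(Nc2ccc(Oc3ccccc3)cc2)=CC(=O)c2ncncc21`, is not yet measured. It differs from compound 1 in one place:

phenoxy in place of 4-ethylphenyl on an aromatic carbon

Among the compounds with values here, no step between two measured compounds isolates a change of this kind, so there is no direct guide to its size. The expectation rests on compound 1 alone, whose value 1200 nM shows that a para-substituted anilino group on this core gives a number far from compound 2. The step of a 1.3-fold higher number from compound 1 to compound 4 (0.10 log units; within the scatter) is expected to be small, with no clear direction beyond the scatter. Compound 4 is estimated at 1500 nM, with a range from 500 nM to 5000 nM.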

Compound 4, half-maximal inhibitory concentration: 1800 nM
Estimate against measurement, compound 4: 1.2-fold (0.08 log units) below; low and high end bracket the measured number.
By their numbers in this assay, from the lowest: compounds 3, 1 and 4 (each within the scatter of the next); then compound 2.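

In this assay, phenoxy in place of 4-ethylphenyl on an aromatic carbon, para to a large group, gives a 1.5-fold higher number from compound 1 to compound 4 (0.18 log units; within the scatter). Within the data shown here, this is the first step read at this position, and it shows that the two groups are not distinguished here, even though phenoxy carries an oxygen and a hydrogen-bond acceptor that 4-ethylphenyl lacks. No measured property is available that bears on this result.

From the compounds shown here alone, whether an amine, a carboxylic acid or a methoxy group at this same place would give a step beyond the scatter remains open. Also open, going by these compounds, is whether the exchange of 4-ethylphenyl for phenoxy would give a similar step in a cell line other than the one used here.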